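The compounds below may be only part of what the source reports. "The series", "measured", "known", "first", "only" and "open" are said of these compounds alone.

Working notes on the series in a functional assay on HL-60 cells (Homo sapiens) for antiproliferative activity, read by sulforhodamine B assay, with a stated time of 72 h; a higher number here means a weaker inhibitor, a lower number a stronger inhibitor: compound 1 `Cc1cc(C)nc(NS(=O)(=O)c2ccc(Nc3nncc4ccccc34)cc2)n1` gives 9.5 nM and compound 2 `O=S(=O)(Nc1nccs1)c1ccc(Nc2nncc3ccccc23)cc1` gives 77 nM, so compound 2 holds the higher of the two numbers. Next comes compound 3 `O=S(=O)(Nc1ccccn1)c1ccc(Nc2nncc3ccccc23)cc1`, not yet measured. Its difference from compound 2 is pyridin-2-yl in place of 1,3-thiazol-2-yl on a sulfonamide nitrogen, in short pyridin-2-yl in place of 1,3-thiazol-2-yl on a sulfonamide nitrogen. Going by the values given here, only one measured step bears on this change: an 8.1-fold higher number from compound 1 to compound 2 (0.91 log units; beyond the scatter), a modest step beyond the scatter, with 1,3-thiazol-2-yl in place of 4,6-dimethylpyrimidin-2-yl on a sulfonamide nitrogen. Pyridin-2-yl itself has no measured precedent, so this single step is a thin guide. Partial recovery toward compound 1 is expected, without a full return. The expected move is a 2.6-fold lower number from compound 2 to compound 3 (0.41 log units; beyond the scatter), a modest step toward a lower number. For compound 3 the estimate is 30 nM, with an expected range of 9 nM to 100 nM.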

Compound 3, half-maximal inhibitory concentration: 86 nM
Compound 3: the middle estimate sits 2.9-fold (0.46 log units) below what was measured; the range from low to high includes it.
By their numbers in this assay, from the lowest: compound 1; then compounds 2 and 3 (each within the scatter of the next).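

In this assay, the five-membered 1,3-thiazol-2-yl and the six-membered pyridin-2-yl on the sulfonamide nitrogen are not told apart: the step is a 1.1-fold higher number from compound 2 to compound 3 (0.05 log units; within the scatter). The comparison with compound 1 now rests on two rings rather than one, with a 9.1-fold higher number from compound 1 to compound 3 (0.96 log units; beyond the scatter) alongside an 8.1-fold higher number from compound 1 to compound 2 (0.91 log units; beyond the scatter), so only the 4,6-dimethylpyrimidin-2-yl compound stands apart from the others. No measurement on hand accounts for this separation.

The compounds shown leave open whether the separation of compound 1 belongs to the two methyl groups or to the pyrimidine ring itself; a plain pyrimidin-2-yl on the same nitrogen would divide the two. Also open, as far as these compounds go, is how a non-aromatic group on this nitrogen, such as acetyl, would read here.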